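This account rests on a few compounds, and the source may have more. Where it says the series, first, only, none or still open, it means among the compounds named here.

Measured in a functional assay on A549 cells (Homo sapiens) for inhibition, read by sulforhodamine B assay, with a stated time of 48 h; a higher number here means a weaker inhibitor of growth, a lower number a stronger inhibitor of growth:

- compound 1 `Cc1ccc(/C=C/C(=O)/C=C(O)/C=C/c2ccc(C)o2)o1`: > 25000 nM (a limit)
- compound 2 `COc1ccc(/C=C/C(=O)C(=Cc2ccc(O)c(OC)c2)C(=O)/C=C/c2ccc(OC)cc2)cc1`: 1640 nM
- compound 3 `COc1ccc(C=C(C(=O)/C=C/c2ccc(O)c(OC)c2)C(=O)/C=C/c2ccc(O)c(OC)c2)c(OC)c1`: 690 nM

Compound 1 gives > 25000 nM, which is a limit and not a number. Of the two numeric values, compound 2 has the higher at 1640 nM and so is the weaker inhibitor of growth. The nearest value is that of compound 3 at 690 nM, and this gap lies beyond the usual scatter.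

The next compound to be measured is compound 4 `COc1ccc(/C=C/C(=O)C(=CO)C(=O)/C=C/c2ccc(OC)cc2)cc1`. Relative to compound 2, it has hydroxy in place of 4-hydroxy-3-methoxyphenyl on a double-bonded chain carbon bound to a double-bonded chain carbon. Among the measured compounds shown here, no measured pair shows this change, so the expectation is tentative. The change removes a whole aromatic substituent, and a clear move toward weaker growth inhibition is expected in this assay, beyond the scatter. Compound 2 at 1640 nM is the starting point. Compound 1 stands at the limit of > 25000 nM in this assay, at which 1 of the 3 values shown sits, so a limit reading is also possible for compound 4. The estimated change is a 3.7-fold higher number from compound 2 to compound 4 (0.56 log units; beyond the scatter), a higher number. Compound 4 is expected at 6000 nM, with an estimated range of 1800 nM to 25000 nM.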

Compound 4, concentration for 50% growth inhibition: > 25000 nM
Compound 4 ended at the assay's limit (the forecaster's own chance of this, stated with the estimate: 30%); middle value at least 4.1-fold (0.61 log units) from the limit.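

In this assay, compound 4 gives > 25000 nM, which is a limit of the assay and not a number. The first one-place change readable in this series, hydroxy in place of 4-hydroxy-3-methoxyphenyl on a double-bonded chain carbon bound to a double-bonded chain carbon, gives an at least 15-fold higher number from compound 2 to compound 4 (1.18 log units; beyond the scatter), so growth inhibition at measurable levels in this pair depends on what sits at this position, and the loss of the aromatic substituent goes with a large step toward weaker inhibition. Compound 4 now shares the ceiling of the assay with compound 1, so a limit reading is no longer confined to the one compound with a different core: the limit of > 25000 nM in this assay, at which 2 of the 4 values shown sit.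

The pair cannot separate the need for an aromatic ring at this position from the need for any larger group, and a cyclohexyl or a dimethylamino group in place of the hydroxy would bear on that question. Compound 2 and compound 3 differ in more than one place, so the role of the substitution on the aromatic ring at this position also stays unresolved.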